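The source may hold more compounds than are shown below. What is called first, only, known or untested is meant among the compounds shown, and "the series" means these compounds.

Two compounds of the series carry numbers in a functional assay on HepG2 cells (Homo sapiens) for inhibition, read by MTT assay, with a stated time of 72 h, tested at 50 uM; on this read-out higher numbers stand for more inhibition of growth at the one concentration tested and lower numbers for less inhibition of growth. Compound 1 `C=CCc1ccc(OCc2cn(-c3ccccc3Cl)nn2)c(O)c1` gives 4.7% in this assay, the lower of the two. Among the measured compounds shown here, compound 2 `C=CCc1cc(O)c(O)c(CN2CCC(C)CC2)c1` gives 69.7% in this assay, a number that lies beyond the scatter above the number of compound 1; no single-place step is recorded between these two, as they differ in more than one place, so their values stand side by side only.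

Compound 3 `C=CCc1ccc(OCc2cn(-c3ccc(OC)cc3)nn2)c(O)c1` is still to be measured in this assay. It differs from compound 1 in one place: 4-methoxyphenyl in place of 2-chlorophenyl on an aromatic nitrogen. For the measured compounds named here, no step between measured compounds matches this change, so the expected size of the step rests on compound 1 alone. Going by the values given here, the number of compound 1, 4.7%, leaves little room for a fall, and nothing among the measured compounds points to a rise from this change. The step is expected to be a number 3.3 percentage points higher from compound 1 to compound 3 (within the scatter), within the scatter. Compound 3 is expected to give 8% in this assay, with a range from 0% to 25%.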

Compound 3, percent growth inhibition at one concentration: 49.9%
Estimate against measurement, compound 3: 41.9 percentage points below; the whole stated range lies below it.
By their numbers in this assay, from the lowest: compound 1; then compound 3; then compound 2.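

In this assay, among the compounds shown here, the group on the aromatic nitrogen of the five-membered aromatic ring with 3 nitrogen proves to be a position that matters: 4-methoxyphenyl in place of 2-chlorophenyl comes with a number 45.2 percentage points higher from compound 1 to compound 3 (beyond the scatter) as the first single-place step. Compound 3 keeps the core of compound 1. No measurement at hand speaks to the reason for this step.

The step exchanges both the substituent and its location on the phenyl ring, and the two compounds cannot tell these apart; 4-chlorophenyl, 2-methoxyphenyl and unsubstituted phenyl on the same nitrogen would separate them. Also open, on these data alone, is how far this position tolerates other kinds of group, such as a phenyl ring bearing a dimethylamino group or a carboxylic acid, or a benzyl group in place of the phenyl ring.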